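The source may report more compounds than this note shows. Statements on the series, on what has been measured and on what is new or still open speak of the compounds shown alone.

Measured so far in a physicochemical assay for lipophilicity, at pH 7.4; on this read-out higher numbers stand for higher lipophilicity and lower numbers for lower lipophilicity:
Compound 1 `Cc1[nH]c2ccccc2c(=O)c1C1CCCCC1`: 2.45
Compound 2 `Cc1[nH]c2ccccc2c(=O)c1Br`: 1.67
Compound 3 `Cc1[nH]c2ccccc2c(=O)c1/C=C/c1ccc(O)cc1`: 1.77

Compound 2 shares the low end of these three numbers with compound 3, as the two lie within the usual scatter of each other. Compound 1 stands clearly apart from that pair.

Compound 4 `Cc1ccc2[nH]c(C)c(Br)c(=O)c2c1` has not been measured yet. It differs from compound 2 in one place, with methyl in place of hydrogen on an aromatic carbon.

Among the measured compounds shown here, the only measured step, a number 0.78 log units lower from compound 1 to compound 2 (beyond the scatter), is modest but beyond the scatter. It is an imperfect guide, since it swaps a different group at a different place. For the measured compounds named here, no measured pair shows what this methyl does, so the size of the new step is a judgement. A small rise is expected, smaller than that measured step, and it may barely clear the scatter. The expected change is a number 0.43 log units higher from compound 2 to compound 4 (beyond the scatter). For compound 4 the estimated value is 2.1, with an expected range from 1.75 to 2.5.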

Compound 4, distribution coefficient: 1.07
Beside the measured number, compound 4's estimate is 1.03 log units above it; measured number outside the range, below it.
By their numbers in this assay, from the lowest: compound 4; then compounds 2 and 3 (each within the scatter of the next); then compound 1.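

In this assay, methyl in place of hydrogen on an aromatic carbon gives a number 0.60 log units lower from compound 2 to compound 4 (beyond the scatter); this is the only step shown on the six-membered aromatic ring of carbon only, as the earlier compounds differ at another place. It shows that adding this single carbon need not raise the number, so at this place the direction of a change cannot be assumed from the added group's name alone. Nothing shown here gives a reason for this direction.

Going by these compounds, it remains open whether another group at this place, such as chloro, methoxy or an amine, would move the number the same way. On these data alone, it is also open whether the same methyl would give a similar step with cyclohexyl in place of bromo.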